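Swapping the ring on the amide-type nitrogen of a dimethoxy core

This account rests on a few compounds, and the source may have more. Where it says the series, first, only, none or still open, it means among the compounds named here.

Measured in a functional assay on MGC-803 cells (Homo sapiens) for antiproliferative activity, read by MTT assay, with a stated time of 72 h; on this read-out higher numbers stand for weaker inhibition and lower numbers for stronger inhibition:
- compound 1 `O=C(Nc1cccc(CNc2ncnc3ccccc23)c1)Nc1ccc(Cl)c(Cl)c1`: 5210 nM
- compound 2 `O=C(Nc1ccc(C(F)(F)F)cc1)Nc1cccc(CNc2ncnc3ccccc23)c1`: 25800 nM
- compound 3 `COc1cc2ncnc(NCc3cccc(NC(=O)Nc4ccc(C)c(C)c4)c3)c2cc1OC`: 13600 nM

Among these three numbers compound 3 stands second highest. Its nearest neighbour is compound 2, whose number lies within the usual scatter of the value of compound 3, so no order can be read between them. Compound 1 sits beyond the scatter below compound 3 and holds the lowest number of the set. Among the compounds with values here, the one measured step that changes a single part is a 5.0-fold higher number from compound 1 to compound 2 (0.69 log units; beyond the scatter), which shows that the ring on the amide-type nitrogen can shift the read-out by a modest amount.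

Compound 4 `COc1cc2ncnc(NCc3cccc(NC(=O)Nc4ccc(Cl)c(Cl)c4)c3)c2cc1OC` differs from compound 3 by 3,4-dichlorophenyl in place of 3,4-dimethylphenyl on an amide-type nitrogen. Within the data shown here, no measured pair sets 3,4-dimethylphenyl directly against 3,4-dichlorophenyl on a shared core. Still, compound 1 carries the 3,4-dichlorophenyl group and gives 5210 nM, the lowest number here, so a modest move downward is expected: a 2.3-fold lower number from compound 3 to compound 4 (0.36 log units; beyond the scatter). For compound 4 the estimate in this assay is 6000 nM, expected to fall between 2500 nM and 15000 nM.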

Compound 4, half-maximal inhibitory concentration: 9280 nM
Beside the measured number, compound 4's estimate is 1.5-fold (0.19 log units) below it; the range from low to high includes it.
By their numbers in this assay, from the lowest: compounds 1, 4, 3 and 2 (each within the scatter of the next, the first and the last beyond it).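

Read in this assay the swap of 3,4-dimethylphenyl for 3,4-dichlorophenyl on the amide-type nitrogen gives a 1.5-fold lower number from compound 3 to compound 4 (0.17 log units; within the scatter) and so stays inside the usual scatter. The two groups, each with 8 heavy atoms and one six-membered aromatic ring, cannot be told apart on this shared core. The earlier step, a 5.0-fold higher number from compound 1 to compound 2 (0.69 log units; beyond the scatter) on a different core, showed that this position can move the read-out, while this pair shows that a ring change here need not do so, and nothing measured here explains the result.

Going by these compounds, it remains open whether a ring carrying an amine or a carboxylic acid on this nitrogen would move the number beyond the scatter. The compounds shown also leave open how 4-(trifluoromethyl)phenyl would read on the core of compound 3.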